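Swapping a phenyl for furan at the second ring position

The compounds below may be only part of what the source reports. "The series", "measured", "known", "first", "only" and "open" are said of these compounds alone.

Of the compounds shown here, three sharing one fused core have been measured in an assay on CHO cells for displacement of a labelled ligand from adenosine receptor A3 (Homo sapiens), read by scintillation counting, with a stated time of 3 h; a lower number here means a stronger inhibitor, a higher number a weaker inhibitor. Compound 1 `COc1ccc(-c2nc(N)c3nc(-c4ccccc4)sc3n2)cc1` gives 46.7 nM in this assay. Compound 2 `Nc1nc(-c2cccc(O)c2)nc2sc(-c3ccccc3)nc12` gives 190 nM, a step of a 4.1-fold higher number from compound 1 to compound 2 (0.61 log units; beyond the scatter). Compound 3 `Nc1nc(-c2ccco2)nc2sc(-c3ccccc3)nc12` gives 2.8 nM, the lowest of the three numbers, reached by a 17-fold lower number from compound 1 to compound 3 (1.22 log units; beyond the scatter) and by a 68-fold lower number from compound 2 to compound 3 (1.83 log units; beyond the scatter). Compound 3 therefore stands clearly apart from the other two, with both gaps beyond the scatter.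

Compound 4 `Nc1nc(-c2ccco2)nc2sc(-c3ccco3)nc12` differs from compound 3 in one place: furan-2-yl in place of phenyl on an aromatic carbon. This is a different place from the one varied among the measured compounds, where the changes concerned the group attached elsewhere on the core. Within the data shown here, no measured step bears directly on exchanging the phenyl at this position. The only hint is indirect: replacing a phenyl-type group with furan-2-yl at the other position gave large lower numbers, as in a 17-fold lower number from compound 1 to compound 3 (1.22 log units; beyond the scatter), but that cannot be transferred to this new position with confidence.

Compound 4 is therefore expected to stay close to compound 3, with an estimated step of a 1.4-fold higher number from compound 3 to compound 4 (0.15 log units; within the scatter) in this assay, which lies within the scatter. The estimate for compound 4 in this assay is 4 nM, with a range from 0.8 nM to 25 nM.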

Compound 4, inhibition constant: 99 nM
For compound 4 the middle estimate is 25-fold (1.39 log units) below the measured one; measured number outside the range, above it.
By their numbers in this assay, from the lowest: compound 3; then compound 1; then compounds 4 and 2 (each within the scatter of the next).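

In this assay, the phenyl on the five-membered aromatic ring with 1 nitrogen and 1 sulfur proves to matter, since furan-2-yl in its place gives a clear loss (a 35-fold higher number from compound 3 to compound 4 (1.55 log units; beyond the scatter)). Furan-2-yl therefore does not act the same way at both places on the shared core: where it replaced 4-methoxyphenyl at the other place, the number fell (a 17-fold lower number from compound 1 to compound 3 (1.22 log units; beyond the scatter)), whereas here, replacing phenyl, it rises, so a gain at one place does not carry over to the other. Nothing measured here explains this difference between the two places.

Only one replacement for the phenyl is shown at this position, so these compounds cannot tell whether the phenyl itself is needed or furan-2-yl is simply a poor fit among many workable groups. A thiophen-2-yl, a cyclohexyl or a phenyl carrying a methoxy group at this same carbon, with the furan-2-yl of compound 3 kept at the other place, would begin to separate those two readings.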